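Clearance after a change on the carbonyl carbon

The source may hold more compounds than are shown below. What is called first, only, known or untested is meant among the compounds shown, and "the series" means these compounds.

Measured in an ADME assay on the whole organism (strain Sprague-Dawley) for pharmacokinetics, with Rattus norvegicus as the target, read by LC-MS, using cassette dosing, at a dose of 0.5 mg/kg by the intravenous route; on this read-out higher numbers stand for fast clearance and lower numbers for slow clearance:
Compound 1 `Cc1cc(C#N)cnc1C(=O)Nc1ccc(F)c([C@]2(C)C=C(CF)OC(N)=N2)c1`: 21.8 mL/min/kg
Compound 2 `C[C@@]1(c2cc(NC(=O)c3coc(C(F)F)n3)ccc2F)C=C(CF)OC(N)=N1`: 28.4 mL/min/kg

In this assay compound 2 gives 28.4 mL/min/kg, which lies within the scatter of compound 1, so the two cannot be told apart. Compound 3 `C[C@@]1(c2cc(NC(=O)c3cnc(C(F)F)cn3)ccc2F)C=C(CF)OC(N)=N1` has one structural change: 5-(difluoromethyl)pyrazin-2-yl in place of 2-(difluoromethyl)-1,3-oxazol-4-yl on a carbonyl carbon. For the measured compounds named here, the only measured step at this place, on a carbonyl carbon, is a 1.3-fold higher number from compound 1 to compound 2 (0.11 log units; within the scatter), and it stays within the scatter. One small step is thin evidence, but no change beyond the scatter is expected here. The estimated step is a 1.1-fold lower number from compound 2 to compound 3 (0.06 log units; within the scatter). In this assay, compound 3 is expected at about 25 mL/min/kg, with an estimated range of 13 mL/min/kg to 48 mL/min/kg.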

Compound 3, clearance: 48.1 mL/min/kg
Beside the measured number, compound 3's estimate is 1.9-fold (0.28 log units) below it; measured number above the stated range.
By their numbers in this assay, from the lowest: compounds 1, 2 and 3 (each within the scatter of the next, the first and the last beyond it).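

In this assay this place on the carbonyl carbon now gives a step beyond the scatter: a 2.2-fold higher number from compound 1 to compound 3 (0.34 log units; beyond the scatter) is a modest one, with 5-(difluoromethyl)pyrazin-2-yl in place of 5-cyano-3-methylpyridin-2-yl. Between the two difluoromethyl rings, a 1.7-fold higher number from compound 2 to compound 3 (0.23 log units; within the scatter) shows that the five-membered and six-membered rings cannot be told apart here. No measurement at hand accounts for either step. Still open, from the compounds shown here alone, is how clearance would respond to a phenyl ring on the carbonyl carbon, or to trifluoromethyl in place of difluoromethyl on the pyrazin-2-yl ring.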